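A methyl group added to the pendant phenyl ring

The source may hold more compounds than are shown below. What is called first, only, known or untested is meant among the compounds shown, and "the series" means these compounds.

Among the measured compounds shown here, compound 2 `Cc1ccc(Nc2nc(SCc3cn(Cc4ccccc4Cl)nn3)nc(-c3ccccc3)c2C#N)cc1` is the one compound here with a real number: in a functional assay on MCF7 cells (Homo sapiens) for inhibition, read by MTT assay, with a stated time of 72 h (on this read-out higher numbers stand for weaker inhibition and lower numbers for stronger inhibition), compound 2 gives 9420 nM. Compound 1 `Cc1ccc(Cn2cc(CSc3nc(Nc4ccc(C)cc4)c(C#N)c(-c4ccccc4)n3)nn2)cc1` gives only a limit in this assay, > 64000 nM, which marks the edge of the measurement rather than a value. For the measured compounds named here, the single measured step, an at least 6.7-fold lower number from compound 1 to compound 2 (0.83 log units; beyond the scatter), concerns the group on the saturated chain carbon bound to the aromatic nitrogen, and at that size it stands beyond the usual scatter, though one end of it rests on (the limit of > 64000 nM in this assay, at which 1 of the 2 values shown sits).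

Compound 3 `Cc1ccc(Nc2nc(SCc3cn(Cc4ccccc4Cl)nn3)nc(-c3ccc(C)cc3)c2C#N)cc1` differs from compound 2 at a different place: methyl in place of hydrogen on an aromatic carbon, on the phenyl ring attached to the shared core. No measured step touches this ring, so the step from compound 1 to compound 2 offers no direct guide, and the small size of the change gives no reason to expect a shift beyond the scatter in this assay. Compound 3 is therefore estimated at about 9000 nM, with a likely range from 3000 nM to 30000 nM. The expected step this implies is a 1.0-fold lower number from compound 2 to compound 3 (0.02 log units; within the scatter).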

Compound 3, half-maximal inhibitory concentration: 30900 nM
The estimate for compound 3 lay 3.4-fold (0.54 log units) below the measured number; the whole stated range lies below it.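

Among the compounds shown here, the ring on the shared core, which no earlier step touched, proves sensitive to change: in this assay, methyl in place of hydrogen on an aromatic carbon, para to a large group, gives a 3.3-fold higher number from compound 2 to compound 3 (0.52 log units; beyond the scatter), so inhibition weakens. Adding a single carbon, turning phenyl into 4-methylphenyl, is therefore enough to move the result beyond the scatter, and this step rests on two real numbers rather than on a limit. Nothing measured among these compounds explains why this methyl has that effect.

Hydrogen and methyl are the only two groups shown at this place, so it remains unclear whether the weaker inhibition belongs to methyl alone or would follow from any group placed there. A chlorine atom, a methoxy group or an amine at the same place would begin to answer that, and would show whether the number keeps rising with other groups or falls back towards the value of the unsubstituted phenyl ring.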